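Bromo to Chloro on the Pendant Aryl of Compound 3

The compounds below may be only part of what the source reports. "The series", "measured", "known", "first", "only" and "open" are said of these compounds alone.

Of the compounds shown here, three of the shared core have been measured in a functional assay on B16-F10 cells (Homo sapiens) for cytotoxicity against B16-F10 (Mus musculus), read by MTT assay, with a stated time of 72 h; a higher number here means that more compound is needed for the effect, a lower number that less compound is needed. Compound 1 `O=C1/C(=C\c2ccc(O)cc2)c2ccccc2N1c1c(Cl)cccc1Cl` gives 33 ug/mL. Compound 2 `O=C1/C(=C\c2ccc(F)cc2)c2ccccc2N1c1c(Cl)cccc1Cl` gives 38 ug/mL, and the step of a 1.2-fold higher number from compound 1 to compound 2 (0.06 log units; within the scatter) separates the two only within the scatter. Compound 3 `O=C1/C(=C\c2cccc(Br)c2)c2ccccc2N1c1c(Cl)cccc1Cl` gives 8 ug/mL, the lowest of the three numbers; the steps of a 4.1-fold lower number from compound 1 to compound 3 (0.62 log units; beyond the scatter) and a 4.8-fold lower number from compound 2 to compound 3 (0.68 log units; beyond the scatter) both lie beyond the scatter, so compound 3 stands apart from the other two on this read-out.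

Compound 4 `O=C1/C(=C\c2cccc(Cl)c2)c2ccccc2N1c1c(Cl)cccc1Cl` has not been measured. It differs from compound 3 in one place: chloro in place of bromo on an aromatic carbon. For the measured compounds named here, no measured step exchanges one halogen for another on the same ring carbon. The two steps that reach compound 3 replace the whole pendant ring together with its substitution pattern, and the step between compound 1 and compound 2 replaces hydroxy with fluoro and stays within the scatter. A halogen exchange of this kind is the smallest change in the set, so in this assay no step beyond the scatter is expected, in either direction.

Compound 4 is therefore estimated at 10 ug/mL, with a range of 5 ug/mL to 20 ug/mL. The expected step of a 1.3-fold higher number from compound 3 to compound 4 (0.10 log units; within the scatter) is estimated to fall within the scatter.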

Compound 4, concentration for half-maximal effect: 8 ug/mL
Estimate against measurement, compound 4: 1.3-fold (0.10 log units) above; the measured number falls inside the stated range.
By their numbers in this assay, from the lowest: compounds 3 and 4 (each within the scatter of the next); then compounds 1 and 2 (each within the scatter of the next).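

In this assay, for the compounds shown here, the exchange of 3-bromophenyl for 3-chlorophenyl is the first step that changes one halogen for another on the same ring carbon, and it separates the two compounds by nothing beyond the scatter (no change at the digits printed from compound 3 to compound 4 (within the scatter)); at this place, on an aromatic carbon meta to a large group, the read-out does not tell chloro from bromo. The lower numbers therefore no longer rest on compound 3 alone, as the 3-chlorophenyl compound shows the same separation from the other two (a 4.8-fold lower number from compound 2 to compound 4 (0.68 log units; beyond the scatter); a 4.1-fold lower number from compound 1 to compound 4 (0.62 log units; beyond the scatter)), though each of these steps replaces the whole pendant ring. No measured finding is available to explain the match between the two halogens.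

These larger steps change the substituent and its ring place together, so the compounds shown do not separate the contribution of the group from that of its place. Going by these compounds, how fluoro, an amine or a carboxylic acid on this same ring carbon would read remains open.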